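From bromo to methyl on the shared core

A few compounds are considered here, and "the series" means these few. Any claim that something is new, unique, unknown or untested is made for them only; others in the source may bear on it.

- compound 1 `CO/N=C1/C(=O)N(CCCCCCC(=O)NO)c2ccccc21`: 1710 nM
- compound 2 `CO/N=C1/C(=O)N(CCCCCCC(=O)NO)c2ccc(F)cc21`: 2420 nM
- compound 3 `CO/N=C1/C(=O)N(CCCCCCC(=O)NO)c2ccc(Br)cc21`: 7790 nM

All three values come from a functional assay on MCF7 cells (Homo sapiens) for antiproliferative activity, read by sulforhodamine B assay, with a stated time of 48 h; a lower number here means a stronger inhibitor, a higher number a weaker inhibitor. Compound 3 has the highest number of the three, which makes it the weakest inhibitor here. Compound 4 `CO/N=C1/C(=O)N(CCCCCCC(=O)NO)c2ccc(C)cc21` carries methyl in place of bromo on an aromatic carbon.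

Among the measured compounds shown here, three measured steps bear on this change. Bromo in place of hydrogen gave a 4.6-fold higher number from compound 1 to compound 3 (0.66 log units; beyond the scatter), and bromo in place of fluoro gave a 3.2-fold higher number from compound 2 to compound 3 (0.51 log units; beyond the scatter). Both are modest, while fluoro in place of hydrogen gave a 1.4-fold higher number from compound 1 to compound 2 (0.15 log units; within the scatter). For the measured compounds named here, no methyl compound has been measured, so only a modest step to a lower number is expected in this assay. The expected change is a 2.2-fold lower number from compound 3 to compound 4 (0.35 log units; beyond the scatter). Compound 4 is estimated at 3500 nM, with an expected range of 1500 nM to 8000 nM.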

Compound 4, half-maximal inhibitory concentration: 16700 nM
The estimate for compound 4 lay 4.8-fold (0.68 log units) below the measured number; measured number above the stated range.
By their numbers in this assay, from the lowest: compounds 1 and 2 (each within the scatter of the next); then compound 3; then compound 4.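

In this assay, methyl on this aromatic carbon makes compound 4 the weakest inhibitor of the four, with a 2.1-fold higher number from compound 3 to compound 4 (0.33 log units; beyond the scatter), so exchanging one heavy atom for another here still moves the number beyond the scatter. The loss grows against the fluoro compound, with a 6.9-fold higher number from compound 2 to compound 4 (0.84 log units; beyond the scatter), and against the compound carrying hydrogen, with a 9.8-fold higher number from compound 1 to compound 4 (0.99 log units; beyond the scatter). No measurement at hand explains this order. As far as these compounds go, whether an amine or a nitrile on this carbon would give a number lower than that of compound 1 stays open.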